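This account rests on a few compounds, and the source may have more. Where it says the series, first, only, none or still open, it means among the compounds named here.

Compound 1 `CC1=C(C(=O)O)C(c2cccc(O)c2)NC(=O)N1`: > 10000 nM
Compound 2 `CC1=C(C(=O)NCC2CCCCC2)C(c2cccc(O)c2)NC(=O)N1`: "not determined" (no result reported)
Compound 3 `CC(C)C1=C(C(=O)OCC2CCCCC2)C(c2cccc(O)c2)NC(=O)N1`: "not determined" (no result reported)

Going by the values given here, all three compounds are measured in an ADME assay on CEMx174 cells (Homo sapiens) for cytotoxicity (a higher number here means that more compound is tolerated, a lower number that less compound is tolerated), but only one entry carries a reading. Compound 1 gives > 10000 nM, which is a limit of the assay and not a number. Compound 3 has the entry "not determined" (no result reported), so it has no value of its own and no place on the scale. Among the compounds with values here, that leaves no measured step to serve as a guide.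

Compound 4 `O=C1NC(c2ccccc2)=C(C(=O)OCC2CCCCC2)C(c2cccc(O)c2)N1` has not yet been measured. The change is phenyl in place of isopropyl on a double-bonded ring carbon, with phenyl in place of isopropyl on a double-bonded ring carbon. With no number for compound 3, the size of this step cannot be read from the data. Within the data shown here, the expectation is that the swap brings no shift beyond the scatter in either direction, so the only reading, (the limit of > 10000 nM in this assay, at which 1 of the 3 values shown sits), remains the rough guide. For compound 4 the estimated half-maximal cytotoxic concentration is 20000 nM, with an expected range from 5000 nM to 100000 nM.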

Compound 4, half-maximal cytotoxic concentration: > 10000 nM
Compound 4 gave a limit, no number; the forecaster's own chance of this, stated with the estimate: 60%; the middle value does not contradict the limit.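

In this assay compound 4 gives > 10000 nM, which is a limit and not a number. Going by these compounds alone, compound 3 has no single number, and no step from compound 3 to compound 4 can be read. The compounds shown leave open whether phenyl in place of isopropyl changes how much compound the cells tolerate.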